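Methoxy count on the benzylidene ring: compound 2 to compound 3

The source may hold more compounds than are shown below. What is called first, only, known or untested is meant among the compounds shown, and "the series" means these compounds.

In an assay on HL-60 cells for inhibition of glutathione S-transferase P (Homo sapiens), read by spectrophotometry, tested at 20 uM (a higher number here means more inhibition at the concentration tested (going by the name of the read-out), a lower number less inhibition), compound 2 `COc1ccc(/C=C2\CN(CC(=O)O)c3c(C)cccc3C2=O)c(OC)c1OC` gives 1.57%. The only comparator, compound 1 `COc1ccccc1/C=C1\CN(CC(=O)O)c2c(C)cccc2C1=O`, gives 4.72% in this assay, and the two numbers lie within the usual scatter of each other, so neither compound separates from the other. Compound 3 `COc1ccc(/C=C2\CN(CC(=O)O)c3c(C)cccc3C2=O)c(OC)c1` differs from compound 2 by hydrogen in place of methoxy on an aromatic carbon. Going by the values given here, no step between measured compounds is available for this change; since both measured compounds sit near the floor of the read-out, the step from compound 2 to compound 3 is expected to be none beyond the scatter, a number 1.4 percentage points higher from compound 2 to compound 3 (within the scatter). Compound 3 is accordingly estimated at 3%, with a range from -5% to 12%.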

Compound 3, a percentage reported as inhibition, at one concentration (the size of the read-out at that concentration, not a potency): 11.7%
Compound 3: the middle estimate sits 8.7 percentage points below what was measured; measured number inside the range.
By their numbers in this assay, from the lowest: compounds 2, 1 and 3 (each within the scatter of the next, the first and the last beyond it).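

In this assay, going by these compounds alone, hydrogen in place of the methoxy ortho to two methoxy groups gives the only step that lies beyond the scatter (a number 10.1 percentage points higher from compound 2 to compound 3 (beyond the scatter)). The other single change, methoxy in place of hydrogen on an aromatic carbon, does not separate its pair (a number 7 percentage points higher from compound 1 to compound 3 (within the scatter)). Nothing available bears on why the position responds to this change. All values remain low, so whether the step would hold on repeat measurement is open. Also open, as far as these compounds go, is how an amine or a hydroxyl group would behave at this position.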